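A few compounds are considered here, and "the series" means these few. Any claim that something is new, unique, unknown or untested is made for them only; others in the source may bear on it.

Measured compounds:
compound 1 `Nc1ccccc1NC(=O)c1ccc(CSc2nccc(C(F)(F)F)n2)cc1` — 80.1%
compound 2 `Cc1cc(C)cc(SCc2ccc(C(=O)Nc3ccccc3N)cc2)c1` — 74.7%

In a functional assay on A-375 cells (Homo sapiens) for inhibition, read by CCK-8 assay, with a stated time of 72 h, tested at 8 uM (on this read-out higher numbers stand for more inhibition of growth at the one concentration tested and lower numbers for less inhibition of growth), compound 2 gives the lowest of the two numbers, yet compound 1, with 80.1%, lies within the scatter of it, so the two cannot be ordered. Compound 3 `Nc1ccccc1NC(=O)c1ccc(CSCCc2ccccc2)cc1` has not been measured; it differs from compound 2 in one place: phenethyl in place of 3,5-dimethylphenyl on a sulfur. For the measured compounds named here, no step between measured compounds guides this change, so a shift of either direction no larger than the scatter is expected, with the chance of a modest fall. Compound 3 is therefore estimated at 70%, in the range 52% to 84%, a step of a number 4.7 percentage points lower from compound 2 to compound 3 (within the scatter).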

Compound 3, percent growth inhibition at one concentration: 69.9%
Compound 3: middle estimate off by 0.1 percentage points, on the high side; low and high end bracket the measured number.
By their numbers in this assay, from the lowest: compounds 3, 2 and 1 (each within the scatter of the next, the first and the last beyond it).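

In this assay the exchange of 3,5-dimethylphenyl for phenethyl on a sulfur gives a number 4.8 percentage points lower from compound 2 to compound 3 (within the scatter) and so this position accepts a phenyl ring carried on a saturated chain as well as an aromatic ring bonded directly to the sulfur, with no difference beyond the scatter. No measurement bears on why these two groups give such similar numbers. The compounds shown leave open whether a longer chain on this sulfur, or a chain ending in an amine or a carboxylic acid, would keep the inhibition of growth.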